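Phenoxy for bromo in a cytotoxicity series

This account rests on a few compounds, and the source may have more. Where it says the series, first, only, none or still open, it means among the compounds named here.

Compound 1, `O=c1[nH]c(=O)n([C@H]2C[C@H](O)[C@@H](CO)O2)cc1-c1cnnn1-c1c(F)cccc1F`: in an ADME assay on HEL cells (Homo sapiens) for cytotoxicity, read by cell counting, with a stated time of 3 days (on this read-out higher numbers stand for lower toxicity in this test and lower numbers for higher toxicity in this test), compound 1 gives > 100000 nM, which is a limit of the assay.
Compound 2, `CC(C)c1ccc(-n2nncc2-c2cn([C@H]3C[C@H](O)[C@@H](CO)O3)c(=O)[nH]c2=O)cc1`: in this assay compound 2 gives > 100000 nM, again a limit.
Compound 3, `O=c1[nH]c(=O)n([C@H]2C[C@H](O)[C@@H](CO)O2)cc1-c1cnnn1-c1ccc(Br)cc1`: in this assay compound 3 gives > 100000 nM, also a limit.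

Compound 3 thus stands at the limit of > 100000 nM in this assay, at which 3 of the 3 values shown sit, and no measured value rises above or falls below it. The steps a step that the two limits leave unreadable from compound 1 to compound 2, a step that the two limits leave unreadable from compound 1 to compound 3 and a step that the two limits leave unreadable from compound 2 to compound 3 are each bounded on both sides by limits, so none of them yields a readable size.

Compound 4, `O=c1[nH]c(=O)n([C@H]2C[C@H](O)[C@@H](CO)O2)cc1-c1cnnn1-c1ccc(Oc2ccccc2)cc1`, differs from compound 3 as follows: phenoxy in place of bromo on an aromatic carbon. The step that bears most directly on it is a step that the two limits leave unreadable from compound 2 to compound 3, which exchanges one group on the same aromatic carbon; it is unreadable, and so are the two others. Nothing measured therefore points to a direction, and the expected step of a number no higher from compound 3 to compound 4 (the limit leaves the size open) is none beyond the scatter. Compound 4 is estimated at 100000 nM in this assay, with a range from 30000 nM to 300000 nM, most probably reported again as a limit.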

Compound 4, minimum cytotoxic concentration: > 100000 nM
Compound 4: a limit, no number (the forecaster's own chance of this, stated with the estimate: 70%); the middle value lies on the limit itself.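

In this assay, within the data shown here, compound 4 gives > 100000 nM, a limit, and no step from compound 2 or compound 3 to compound 4 can be read. The compounds shown leave open at what concentration, if any, their aryl groups would separate them in cytotoxicity: the limit of > 100000 nM in this assay, at which 4 of the 4 values shown sit.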